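Methylamino for Methoxy on a Benzofuran Nucleoside

The source may hold more compounds than are shown below. What is called first, only, known or untested is meant among the compounds shown, and "the series" means these compounds.

Compound 1 `COc1ncnc2c1c(-c1cccs1)cn2[C@@H]1O[C@H](CO)[C@@H](O)[C@H]1O` and compound 2 `CNc1ncnc2c1c(-c1cccs1)cn2[C@@H]1O[C@H](CO)[C@@H](O)[C@H]1O` share a core and differ only as described: methylamino in place of methoxy on an aromatic carbon. In a functional assay on CEM-DNR-bulk cells (Homo sapiens), read by MTT assay, with a stated time of 72 h (on this read-out lower numbers stand for stronger inhibition and higher numbers for weaker inhibition), compound 1 gives 12100 nM. For compound 2 this assay reports a limit rather than a number, > 20000 nM. Within the data shown here, the step is therefore an at least 1.6-fold higher number from compound 1 to compound 2 (0.21 log units; that floor lies within the scatter), and the only evidence about its size is the limit of > 20000 nM in this assay, at which 1 of the 3 values shown sits.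

Compound 3 `COc1ncnc2c1c(-c1cc3ccccc3o1)cn2[C@@H]1O[C@H](CO)[C@@H](O)[C@H]1O` differs from compound 1 by 1-benzofuran-2-yl in place of thiophen-2-yl on an aromatic carbon. In this assay compound 3 gives 10800 nM, a step of a 1.1-fold lower number from compound 1 to compound 3 (0.05 log units; within the scatter).

Compound 4 `CNc1ncnc2c1c(-c1cc3ccccc3o1)cn2[C@@H]1O[C@H](CO)[C@@H](O)[C@H]1O` has not yet been measured. It differs from compound 3 by methylamino in place of methoxy on an aromatic carbon, the same change that separates compound 1 from compound 2, at the same place in the same words. The expected step is a 2.3-fold higher number from compound 3 to compound 4 (0.36 log units; beyond the scatter), resting on the step of an at least 1.6-fold higher number from compound 1 to compound 2 (0.21 log units; that floor lies within the scatter) seen with the same change. Compound 4 is estimated to give 25000 nM, with a likely range from 12000 nM to 60000 nM, and a real chance that this assay again reports only a limit.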

Compound 4, half-maximal inhibitory concentration: > 20000 nM
Compound 4 ended at the assay's limit; the forecaster's own chance of this, stated with the estimate: 65%; the middle value lies beyond the limit too.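

On the benzofuran core, methylamino in place of methoxy gives an at least 1.8-fold higher number from compound 3 to compound 4 (0.26 log units; that floor lies within the scatter), so on both cores the methylamino compound ends at a limit of this assay while its methoxy partner keeps a readable number. On these data alone, the change therefore carries over in the sense that neither core yields a methylamino compound with a measured value, but the size of the step on each core stays unknown, and no claim can be made that it is the same on both: the same change on two cores in this assay, an at least 1.6-fold higher number (0.21 log units; that floor lies within the scatter) from compound 1 to compound 2 and an at least 1.8-fold higher number (0.26 log units; that floor lies within the scatter) from compound 3 to compound 4; the limit leaves it open whether they differ. The step from compound 2 to compound 4 cannot be read either, so nothing can be said about how thiophen-2-yl and 1-benzofuran-2-yl compare when methylamino is present, because both compounds stop at the same ceiling: the limit of > 20000 nM in this assay, at which 2 of the 4 values shown sit.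

The compounds shown leave open whether a plain amino group or a dimethylamino group on that aromatic carbon would give a readable number in this assay. They also leave open whether ethoxy, a longer chain than methoxy, would hold the activity seen with compound 1 and compound 3.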